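A few compounds are considered here, and "the series" means these few. Any claim that something is new, unique, unknown or untested is made for them only; others in the source may bear on it.

The measured compounds:
Compound 1 `COc1ccc(CNc2nc([SeH])nc3ccccc23)cc1` — in an ADME assay on BEAS-2B cells (Homo sapiens) for cytotoxicity, read by MTT assay, with a stated time of 72 h (on this read-out higher numbers stand for weaker inhibition of growth and lower numbers for stronger inhibition of growth), compound 1 reaches only the limit of > 100000 nM.
Compound 2 `CSc1nc(NCCCCCO)c2ccccc2n1` — in this assay compound 2 gives 99400 nM.
Compound 3 `COc1ccc(CNc2nc(SC)nc3ccccc23)cc1` — in this assay compound 3 gives 96200 nM.

Compound 1 stands at the top end of what is shown: its value is a limit of the assay rather than a number (the limit of > 100000 nM in this assay, at which 1 of the 3 values shown sits). The other two compounds give numbers just short of that ceiling, so all three sit close together. Compound 4 `CSc1ccc(CNc2nc([SeH])nc3ccccc23)cc1` has not yet been measured in this assay. methylsulfanyl in place of methoxy on an aromatic carbon One measured step bears on this change, though only loosely: an at least 1.0-fold lower number from compound 1 to compound 3 (0.01 log units; that floor lies within the scatter), where a methylsulfanyl group also entered, but in place of a selenium atom. That step stayed within the scatter, and no step shown moves outside it. The change from compound 1 to compound 4 is therefore expected to give no step beyond the scatter in this assay, in either direction. Compound 4 is estimated at 100000 nM, with an expected range from 50000 nM to 200000 nM, and a real chance that it returns only a limit. This estimate means an expected a number no higher from compound 1 to compound 4 (the limit leaves the size open).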

Compound 4, concentration for total growth inhibition: 58200 nM
Estimate against measurement, compound 4: 1.7-fold (0.24 log units) above; the measured number falls inside the stated range.
By their numbers in this assay, from the lowest: compounds 4, 3 and 2 (each within the scatter of the next). At a limit, above all of these: compound 1.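

For the compounds shown here, the only earlier step changed the selenium atom, whereas this one leaves it in place and acts on a different part of the molecule: methylsulfanyl in place of methoxy, on an aromatic carbon para to a large group, gives an at least 1.7-fold lower number from compound 1 to compound 4 (0.23 log units; that floor lies within the scatter) in this assay. Compound 4 is the only compound shown that carries the selenium atom and returns a number, so this position can alter the read-out enough to yield a measurable value. The step remains only a floor, and the real size of the change cannot be read, because compound 1 has a limit rather than a number: the limit of > 100000 nM in this assay, at which 1 of the 4 values shown sits.

The compounds shown leave open whether this position would respond differently to an amine, a carboxylic acid or a longer chain in place of methoxy. They also leave open whether the same swap would have a comparable effect when the selenium atom is replaced by the methylsulfanyl group carried by compound 3.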